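The compounds below may be only part of what the source reports. "The series", "measured", "known", "first", "only" and "open" are said of these compounds alone.

Compound 1 `Cc1cccc(S(=O)(=O)N2CCC(N3CCC(C)CC3)CC2)c1`: 25 nM
Compound 2 `CC1CCN(C2CCN(S(=O)(=O)c3nccn3C)CC2)CC1`: > 5000 nM
Compound 3 `CC1CCN(C2CCN(S(=O)(=O)c3cc(Cl)cc(Cl)c3)CC2)CC1`: 3400 nM

In a functional assay on DLD-1 cells (Homo sapiens) for antiproliferative activity, read by CellTiter-Glo, with a stated time of 72 h (on this read-out higher numbers stand for weaker inhibition and lower numbers for stronger inhibition), compound 1 gives the lowest number of those measured; compound 3 stands a 140-fold higher number from compound 1 to compound 3 (2.13 log units; beyond the scatter) away. For compound 2 this assay reports only a limit, (the limit of > 5000 nM in this assay, at which 1 of the 3 values shown sits). Compound 4 `Cc1cc(C)cc(-c2cccc(S(=O)(=O)N3CCC(N4CCC(C)CC4)CC3)c2)c1` differs from compound 1 by 3,5-dimethylphenyl in place of methyl on an aromatic carbon. Neither measured step touches that methyl alone: both an at least 200-fold higher number from compound 1 to compound 2 (2.30 log units; beyond the scatter) and a 140-fold higher number from compound 1 to compound 3 (2.13 log units; beyond the scatter) exchange the whole ring on the sulfonyl sulfur, and each loss was large. The step to compound 4 keeps that ring and only extends it, so a smaller loss than those is expected, with wide uncertainty. Compound 4 is estimated at 300 nM (from 40 nM to 3000 nM), an expected step of a 12-fold higher number from compound 1 to compound 4 (1.08 log units; beyond the scatter).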

Compound 4, half-maximal inhibitory concentration: 41 nM
Estimate against measurement, compound 4: 7.3-fold (0.86 log units) above; the measured number falls inside the stated range.
By their numbers in this assay, from the lowest: compounds 1 and 4 (each within the scatter of the next); then compound 3. At a limit, above all of these: compound 2.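

In this assay the step of a 1.6-fold higher number from compound 1 to compound 4 (0.21 log units; within the scatter) shows that this aromatic carbon, meta to a large group, can hold 3,5-dimethylphenyl in place of methyl with no readable change. Compounds 2 and 3 showed large losses only when the whole ring on the sulfonyl sulfur was exchanged, whereas compound 4 shows that this ring can carry a much larger group without such a loss. Nothing measured here explains this tolerance.

On these data alone, what an amine or a carboxylic acid on this carbon would do stays open. So does whether an unsubstituted phenyl would behave like 3,5-dimethylphenyl.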